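Acid dissociation in the series; expectation for compound 4

The compounds below may be only part of what the source reports. "The series", "measured", "known", "first", "only" and "open" are said of these compounds alone.

Values in a physicochemical assay for acid dissociation, so far:
compound 1 `Clc1ccc(Oc2ccc3c(NCCCNCc4ccco4)ccnc3c2)cc1` gives 9.28.
compound 2 `COc1cccc(CNCCCNc2ccnc3cc(Oc4cccc(N(C)C)c4)ccc23)c1O` gives 9.28.
compound 3 `COc1cccc(CNCCCNc2ccnc3cc(Cc4ccc(C#N)cc4)ccc23)c1O` gives 9.47.

Compound 3 has the highest of the three numbers, but its gaps to compound 1 and to compound 2 both lie within the scatter, so no order among the three can be read from them. Compound 4 `COc1cccc(CNCCCNc2ccnc3cc(Oc4ccc(Cl)cc4)ccc23)c1O` has not yet been measured. It differs from compound 3 at one place: 4-chlorophenoxy in place of 4-cyanobenzyl on an aromatic carbon.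

Among the compounds with values here, one measured step bears on this change, an exchange at the same aromatic carbon: a number 0.19 log units higher from compound 2 to compound 3 (within the scatter). Compound 1 carries the same 4-chlorophenoxy group that enters here, with a different remainder of the molecule, and compound 1 gives 9.28. Both observations point to no step beyond the scatter, so the estimated step is a number 0.17 log units lower from compound 3 to compound 4 (within the scatter). Compound 4 is therefore expected to give 9.3 in this assay, with a range from 9 to 9.6.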

Compound 4, acid dissociation constant: 9.28
Compound 4: middle estimate off by 0.02 log units, on the high side; the measured number falls inside the stated range.
By their numbers in this assay, from the lowest: compounds 1, 2, 4 and 3 (each within the scatter of the next).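

In this assay the exchange on this aromatic carbon now has a direct reading for 4-chlorophenoxy in place of 4-cyanobenzyl, a number 0.19 log units lower from compound 3 to compound 4 (within the scatter), so these two groups cannot be told apart here. The two other single exchanges agree: 4-chlorophenyl in place of 3-(dimethylamino)phenyl on the oxygen gives no change at the digits printed from compound 2 to compound 4 (within the scatter), and 2-hydroxy-3-methoxyphenyl in place of furan-2-yl on the saturated chain carbon gives no change at the digits printed from compound 1 to compound 4 (within the scatter). Nothing on hand speaks to the origin of these results.

The compounds shown leave open whether a carboxylic acid or a primary amine on this aromatic carbon, or a longer chain in place of the present one, would move the number beyond the scatter. They also leave open which proton in these molecules this assay reports on.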